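A few compounds are considered here, and "the series" means these few. Any claim that something is new, unique, unknown or untested is made for them only; others in the source may bear on it.

Compound 1 `CCCCCCCC(=O)Nc1ccc2[nH]cc(C3CCN(C)CC3)c2n1` gives 20 nM in an assay for binding affinity to 5-hydroxytryptamine receptor 1F (Homo sapiens), read by radioligand binding; a lower number here means a stronger inhibitor, a higher number a weaker inhibitor; compound 2 `CN1CCC(c2c[nH]c3ccc(NC(=O)c4ccc([N+](=O)[O-])cc4)nc23)CC1` gives 7.7 nM.

Compound 2 holds the lowest of the two numbers measured in this assay, and its nearest neighbour is compound 1. Going by the values given here, the only step seen so far, a 2.6-fold lower number from compound 1 to compound 2 (0.41 log units; beyond the scatter), is a modest one. Compound 3 `CN1CCC(c2c[nH]c3ccc(NC(=O)Nc4ccc(F)cc4)nc23)CC1` differs from compound 2 by (4-fluorophenyl)amino in place of 4-nitrophenyl on a carbonyl carbon. Among the compounds with values here, no measured step bears directly on this exchange, so the expectation is a step no larger than the one already seen, with no sure direction. Compound 3 is therefore expected to give about 10 nM, within 3 nM to 35 nM, meaning a 1.3-fold higher number from compound 2 to compound 3 (0.11 log units; within the scatter).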

Compound 3, inhibition constant: 11 nM
Compound 3: the middle estimate sits 1.1-fold (0.04 log units) below what was measured; low and high end bracket the measured number.
By their numbers in this assay, from the lowest: compounds 2, 3 and 1 (each within the scatter of the next, the first and the last beyond it).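

Swapping 4-nitrophenyl for (4-fluorophenyl)amino on the carbonyl carbon gives a 1.4-fold higher number from compound 2 to compound 3 (0.15 log units; within the scatter) in this assay, so this position takes an added nitrogen and its hydrogen-bond donor with no change that stands clear of the scatter. The swap from heptyl gives a 1.8-fold lower number from compound 1 to compound 3 (0.26 log units; within the scatter) and is also unresolved, even though compound 1 and compound 2 do differ beyond the scatter. Nothing available explains this tolerance.

Open, from the compounds shown here alone, is whether a carboxylic acid or a small amine on the same carbonyl carbon would keep binding in this range, and whether the fluorine itself matters.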